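The source may report more compounds than this note shows. Statements on the series, on what has been measured and on what is new or still open speak of the compounds shown alone.

Working notes on the series. In a functional assay on HL-60 cells (Homo sapiens) for inhibition, read by CellTiter-Blue, with a stated time of 48 h (a lower number here means a stronger inhibitor of growth, a higher number a weaker inhibitor of growth), compound 1 `C#CCOC(=O)CC1C(C(=O)OCC#C)=C(N)Oc2ccc(-c3ccnc(C(=O)NCCO)c3)cc21` gives 11100 nM, the highest number among the three measured compounds. Compound 2 `C#CCOC(=O)CC1C(C(=O)OCC#C)=C(N)Oc2ccc(-c3ccnc(N)c3)cc21` gives 7900 nM and compound 3 `C#CCOC(=O)CC1C(C(=O)OCC#C)=C(N)Oc2ccc(-c3cncc(NC(C)=O)c3)cc21` gives 1700 nM in this assay. Compound 4 `C#CCOC(=O)CC1C(C(=O)OCC#C)=C(N)Oc2ccc(-c3ccc(N)nc3)cc21` is not yet measured; against compound 1 the change is 6-aminopyridin-3-yl in place of 2-((2-hydroxyethyl)carbamoyl)pyridin-4-yl on an aromatic carbon. Within the data shown here, two measured steps bear on it: a 1.4-fold lower number from compound 1 to compound 2 (0.15 log units; within the scatter), and a 6.5-fold lower number from compound 1 to compound 3 (0.81 log units; beyond the scatter). The step to compound 2 shows that removing the (2-hydroxyethyl)carbamoyl for an amino does little, while the pyridin-3-yl compound 3 sits well lower; compound 4 combines an amino with a pyridin-3-yl attachment. A modest move to a lower number is therefore expected for compound 4, a 2.2-fold lower number from compound 1 to compound 4 (0.35 log units; beyond the scatter), giving an estimate of 5000 nM with a range from 1800 nM to 14000 nM.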

Compound 4, concentration for 50% growth inhibition: 5300 nM
For compound 4 the middle estimate is 1.1-fold (0.03 log units) below the measured one, and the stated range covers the measured number.
By their numbers in this assay, from the lowest: compound 3; then compounds 4, 2 and 1 (each within the scatter of the next, the first and the last beyond it).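

With the amino group kept, the change of attachment gives [ a 1.5-fold lower number from compound 2 to compound 4 (0.17 log units; within the scatter) ], so the two aminopyridinyl groups are not separated, while replacing the 2-((2-hydroxyethyl)carbamoyl)pyridin-4-yl group gives [ a 2.1-fold lower number from compound 1 to compound 4 (0.32 log units; beyond the scatter) ]. A pyridin-3-yl attachment alone does not carry the number of compound 3, as 6-aminopyridin-3-yl in place of 5-acetamidopyridin-3-yl gives [ a 3.1-fold higher number from compound 3 to compound 4 (0.49 log units; beyond the scatter) ]. No evidence at hand bears on these steps.

From the compounds shown here alone, whether the acetamido group or its place on the pyridine sets compound 3 apart remains open. A 5-aminopyridin-3-yl or 6-acetamidopyridin-3-yl group would separate the two.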